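Adding a Chloro Group to Compound 3

A few compounds are considered here, and "the series" means these few. Any claim that something is new, unique, unknown or untested is made for them only; others in the source may bear on it.

Of the compounds shown here, three have been measured in a functional assay on the whole organism with Mus musculus as the target, in the maximal electroshock model; a lower number here means that less compound is needed, a higher number that more compound is needed for the effect. Compound 1 `Cc1nn2cnnc2cc1Cc1ccccc1Cl` gives 6 mg/kg, compound 2 `Cc1nn2c(C)nnc2cc1Cc1ccccc1Cl` gives 30.5 mg/kg, and compound 3 `Cc1nn2c(N)nnc2cc1Cc1ccccc1` gives 22 mg/kg. Compound 3 stands second highest of the three numbers; its value and that of compound 2 lie within the scatter of each other, while compound 1 lies beyond the scatter from it. Among the measured compounds shown here, the only measured step, a 5.1-fold higher number from compound 1 to compound 2 (0.71 log units; beyond the scatter), concerns a methyl group and does not touch the present change. Compound 4 `Cc1nn2c(N)nnc2cc1Cc1ccccc1Cl` differs from compound 3 by chloro in place of hydrogen on an aromatic carbon. For the measured compounds named here, no measured step bears directly on this change, and compound 1 and compound 3 differ in two places, so their values cannot be split. Compound 4 is expected at 14 mg/kg, between 6 mg/kg and 35 mg/kg, a step of a 1.6-fold lower number from compound 3 to compound 4 (0.20 log units; within the scatter) that is estimated to be modest.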

Compound 4, dose for half-maximal effect: 17.4 mg/kg
The estimate for compound 4 lay 1.2-fold (0.09 log units) below the measured number; the range from low to high includes it.
By their numbers in this assay, from the lowest: compound 1; then compounds 4, 3 and 2 (each within the scatter of the next).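

In this assay, chloro in place of hydrogen on an aromatic carbon, ortho to a large group, gives a 1.3-fold lower number from compound 3 to compound 4 (0.10 log units; within the scatter), so with the amino group present this change does not move the number beyond the scatter. With the chloro held, amino in place of methyl gives a 1.8-fold lower number from compound 2 to compound 4 (0.24 log units; within the scatter), while amino in place of hydrogen gives a 2.9-fold higher number from compound 1 to compound 4 (0.46 log units; beyond the scatter), so the compound with hydrogen on that carbon stands apart from both. No evidence here accounts for these steps.

The compounds shown leave open whether a bromo or methoxy group in place of the chloro would shift the number beyond the scatter. They also leave open how an ethyl group or a dimethylamino group would compare with amino and methyl.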